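The source may hold more compounds than are shown below. What is called first, only, known or untested is meant among the compounds shown, and "the series" means these compounds.

In a functional assay on MDA-MB-231 cells (Homo sapiens) for antiproliferative activity, read by sulforhodamine B assay, with a stated time of 48 h (a higher number here means a weaker inhibitor of growth, a lower number a stronger inhibitor of growth), compound 1 (`Cc1ccc(-c2nnc(C3=C(Cl)c4cc(C)c(C)cc4CCC3)o2)cc1`) gives 1760 nM while compound 2 (`COc1cc(-c2nnc(C3=C(Cl)c4cc(C)c(C)cc4CCC3)o2)cc(OC)c1OC`) gives 956 nM and compound 3 (`COc1ccc([N+](=O)[O-])c(-c2nnc(C3=C(Cl)c4cc(C)c(C)cc4CCC3)o2)c1OC`) gives 1160 nM on the same read-out. Compound 1 stands within the scatter of both of the others, and the three values do not separate.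

Compound 4 (`Cc1cc2c(cc1C)C(Cl)=C(c1nnc(-c3cccc(I)c3)o1)CCC2`) has no reading yet. It carries 3-iodophenyl in place of 4-methylphenyl on an aromatic carbon. For the measured compounds named here, no measured pair differs in one place only, so this step has no direct precedent.

The three measured compounds carry different groups at that place, yet compound 2 (956 nM) and compound 3 (1160 nM) stay within the scatter of compound 1 (1760 nM). In this assay no step beyond the scatter is therefore expected, and the data favour no clear direction. The expected step of a 1.3-fold lower number from compound 1 to compound 4 (0.10 log units; within the scatter) is an estimate within the scatter. The estimated value for compound 4 (1400 nM) has an expected range of 550 nM to 3500 nM for now.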

Compound 4, concentration for 50% growth inhibition: 2670 nM
Estimate against measurement, compound 4: 1.9-fold (0.28 log units) below; the range from low to high includes it.
By their numbers in this assay, from the lowest: compounds 2, 3, 1 and 4 (each within the scatter of the next, the first and the last beyond it).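

In this assay the series now has its first step that changes one place only (a 1.5-fold higher number from compound 1 to compound 4 (0.18 log units; within the scatter)), with 3-iodophenyl in place of 4-methylphenyl on the aromatic carbon of the five-membered ring. For the compounds shown here, this is the first direct reading at this position: exchanging one substituted phenyl group for the other, with the same count of heavy atoms, does not separate compound 4 from compound 1. No measurement shown accounts for this result.

From the compounds shown here alone, it remains open whether an amine, a carboxylic acid or a longer alkyl chain in place of the substituted phenyl group at this carbon would give a step beyond the scatter. The shared core stays the same throughout, so the compounds shown say nothing about changes made to it.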